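Replacing 4-methylbenzyl with 2-chlorobenzyl on compound 3

This account rests on a few compounds, and the source may have more. Where it says the series, first, only, none or still open, it means among the compounds named here.

Within the data shown here, in a functional assay on MDA-MB-231 cells (Homo sapiens) for cytotoxicity, read by MTT assay, with a stated time of 72 h (on this read-out lower numbers stand for stronger inhibition and higher numbers for weaker inhibition), compound 3 `Cc1ccc(Cn2cc(/C=N/NC(=O)Nc3nc4ccc(CN5CCC(C)CC5)cc4s3)c3ccccc32)cc1` gives 1140 nM and stands lowest of the three numbers measured so far. Compound 2 `CC1CCN(Cc2ccc3nc(NC(=O)N/N=C/c4c[nH]c5ccccc45)sc3c2)CC1` carries only hydrogen on the aromatic nitrogen and gives 2460 nM in this test, while compound 1 `CC1CCN(Cc2ccc3nc(NC(=O)N/N=C/c4cn(Cc5ccc(Cl)cc5Cl)c5ccccc45)sc3c2)CC1` carries 2,4-dichlorobenzyl there and gives 3140 nM as its result.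

The next candidate is compound 4 `CC1CCN(Cc2ccc3nc(NC(=O)N/N=C/c4cn(Cc5ccccc5Cl)c5ccccc45)sc3c2)CC1`. The change is 2-chlorophenyl in place of 4-methylphenyl on a saturated chain carbon bound to an aromatic nitrogen and amounts to 2-chlorophenyl in place of 4-methylphenyl on a saturated chain carbon bound to an aromatic nitrogen. Among the measured compounds shown here, no measured compound carries 2-chlorobenzyl, so the nearest evidence is indirect.

Putting 4-methylphenyl in place of 2,4-dichlorophenyl at this same place gives a 2.8-fold lower number from compound 1 to compound 3 (0.44 log units; beyond the scatter) and counts as a modest change. Putting 4-methylbenzyl in place of hydrogen gives a 2.2-fold lower number from compound 2 to compound 3 (0.33 log units; beyond the scatter) and is also modest. Replacing 2,4-dichlorobenzyl with hydrogen gives a 1.3-fold lower number from compound 1 to compound 2 (0.11 log units; within the scatter) so those two compounds cannot be told apart. Compound 4 gives up the 4-methylbenzyl group, so its number is expected to move back towards those two. The expected change is modest and upward, an estimated 1.8-fold higher number from compound 3 to compound 4 (0.24 log units; within the scatter) in this assay overall. For compound 4 the estimate is 2000 nM with 950 nM to 4200 nM as the expected range.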

Compound 4, half-maximal inhibitory concentration: 1360 nM
Compound 4: middle estimate off by 1.5-fold (0.17 log units), on the high side; measured number inside the range.
By their numbers in this assay, from the lowest: compounds 3, 4, 2 and 1 (each within the scatter of the next, the first and the last beyond it).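

In this assay there is a 1.2-fold higher number from compound 3 to compound 4 (0.08 log units; within the scatter), so 2-chlorobenzyl and 4-methylbenzyl on the aromatic nitrogen cannot be told apart, even though they carry different substituents on the benzyl ring. There is also a 1.8-fold lower number from compound 2 to compound 4 (0.26 log units; within the scatter), which means that compound 4 cannot be told apart from the compound with only hydrogen on that nitrogen either, although compound 3 and compound 2 do differ by more than the scatter. The clearest new information concerns the chloro groups: there is a 2.3-fold lower number from compound 1 to compound 4 (0.36 log units; beyond the scatter), the only step shown that changes nothing but one chloro on the benzyl ring, so 2,4-dichlorobenzyl and 2-chlorobenzyl do differ here, if only modestly.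

No measurement available here explains these differences. Still open, on these data alone, is how 4-chlorobenzyl, with its single chloro in the other ring position, would compare with 2-chlorobenzyl and 2,4-dichlorobenzyl, and whether a methoxy group on the benzyl ring, an amine on it, or a longer chain in place of the benzyl link would move the number beyond the narrow range seen so far.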